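Pyridinyl for sulfamoylphenyl on a thiazole acetic acid core

The source may report more compounds than this note shows. Statements on the series, on what has been measured and on what is new or still open speak of the compounds shown alone.

Measured compounds:
compound 1 `NS(=O)(=O)c1ccc(-c2nc(C(c3ccc(F)cc3)c3ccc(F)cc3)sc2CC(=O)O)cc1` 80%
compound 2 `O=C(O)Cc1sc(CSc2ccccc2)nc1-c1ccc(Cl)cc1` 50%

Both compounds were tested in an in vitro functional assay on HEK285-7 cells for antagonist activity at prostaglandin D2 receptor 2 (Homo sapiens), read by BRET and beta-arrestin recruitment; a lower number here means a smaller maximal response, a higher number a larger maximal response. Compound 1 gives 80%, the higher of the two numbers, while compound 2 gives 50%, a value that falls below compound 1 by more than the usual scatter. Compound 3 `Cc1cc(-c2nc(C(c3ccc(F)cc3)c3ccc(F)cc3)sc2CC(=O)O)cnc1N` has not yet been measured in this assay. It differs from compound 1 in one place: 6-amino-5-methylpyridin-3-yl in place of 4-sulfamoylphenyl on an aromatic carbon. The 4-sulfamoylphenyl group leaves and the 6-amino-5-methylpyridin-3-yl group enters on an aromatic carbon of the shared core, next to the ring nitrogen. Going by the values given here, no measured pair shows such a change, so the size of its effect is unknown. A moderate downward step is expected, a number 10 percentage points lower from compound 1 to compound 3 (within the scatter), though a change within the scatter cannot be ruled out. For compound 3 in this assay the estimated value is 70%, with a range from 45% to 95%.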

Compound 3, largest response reached (reported as efficacy), in percent of the reference or control that the assay uses: 80%
For compound 3 the middle estimate is 10 percentage points below the measured one; the measured number falls inside the stated range.
By their numbers in this assay, from the lowest: compound 2; then compounds 1 and 3 (each within the scatter of the next).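

In this assay the swap of 4-sulfamoylphenyl for 6-amino-5-methylpyridin-3-yl on the aromatic carbon next to the ring nitrogen gives no change at the digits printed from compound 1 to compound 3 (within the scatter). Going by these compounds alone, the earlier compounds offered no pair differing in one place, so this is the first direct reading of a single change at this position. Here a carbon-only ring with 10 heavy atoms and 2 double bonds outside aromatic rings gives way to a ring with 1 hetero atom, 8 heavy atoms and no such double bonds, while the count of 1 hydrogen-bond donor and 2 hydrogen-bond acceptors stays the same.

No measurement shown explains why the response holds at this position. As far as these compounds go, it remains open whether the amine or the methyl group matters on its own, and whether a plain phenyl or a 4-carboxamidophenyl group would give the same response.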